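A ring amine in place of the hydroxypropyl chain

The source may report more compounds than this note shows. Statements on the series, on what has been measured and on what is new or still open speak of the compounds shown alone.

Three measured compounds share one core and differ only in one substituent on the carbon-only aromatic ring. In an ADME assay on cells (Hepatocyte, Rattus norvegicus) for metabolic stability (a lower number here means slower removal, a higher number faster removal of the compound), compound 1, `CC(=O)Nc1cc(Nc2cc(NC3CC3)n3ncc(C#N)c3n2)ccc1N1CC[C@H](N(C)C)C1`, gives 2.5 uL/min. Compound 2, `CC(=O)Nc1cc(Nc2cc(NC3CC3)n3ncc(C#N)c3n2)ccc1N1CCC[C@@H](N(C)C)C1`, sits at a limit of this assay, < 1 uL/min, and so gives no number, as noted in the limit of < 1 uL/min in this assay, at which 1 of the 3 values shown sits. Compound 3, `CC(=O)Nc1cc(Nc2cc(NC3CC3)n3ncc(C#N)c3n2)ccc1NCCCO`, gives 17 uL/min and stands highest of the two numbers shown; its nearest neighbour is compound 1, and the step of a 6.8-fold higher number from compound 1 to compound 3 (0.83 log units; beyond the scatter). Against the limit of compound 2 the step is an at least 17-fold higher number from compound 2 to compound 3 (1.23 log units; beyond the scatter), while an at least 2.5-fold lower number from compound 1 to compound 2 (0.39 log units; beyond the scatter).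

Compound 4, `CC(=O)Nc1cc(Nc2cc(NC3CC3)n3ncc(C#N)c3n2)ccc1N1CCC[C@H](N)C1`, has not yet been measured. It differs from compound 3 as follows: 3-aminopiperidin-1-yl in place of (3-hydroxypropyl)amino on an aromatic carbon. Among the measured compounds shown here, of the measured steps, the one from compound 2 to compound 3 bears most directly on this change, since both compound 2 and compound 4 carry a six-membered non-aromatic ring with one hetero atom at the same carbon, and that step was large. The step from compound 1 to compound 3 points the same way. A large fall in this assay is therefore expected, and the estimated step is an 11-fold lower number from compound 3 to compound 4 (1.05 log units; beyond the scatter). Compound 4 is expected to give 1.5 uL/min, with a likely range from 0.5 uL/min to 5 uL/min.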

Compound 4, intrinsic clearance in a liver preparation (reported as CLH), per the amount of preparation that the assay uses: < 1 uL/min
Compound 4: only a limit was reported (the forecaster's own chance of this, stated with the estimate: 35%); middle value at least 1.5-fold (0.17 log units) away from the limit.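

In this assay, the change to 3-aminopiperidin-1-yl on the aromatic carbon ortho to the acetamido group brings an at least 17-fold lower number from compound 3 to compound 4 (1.23 log units; beyond the scatter), so the fall seen with the two ring amines carrying dimethylamino does not require that dimethylamino group. Against the five-membered ring of compound 1, the result is an at least 2.5-fold lower number from compound 1 to compound 4 (0.39 log units; beyond the scatter), and all three ring amines now lie lower than the (3-hydroxypropyl)amino compound, with none of the compounds shown going against that order. The steps involving compound 2 and compound 4 together cannot be read, and the two six-membered ring amines cannot be ordered, because both compounds sit at the same limit: the limit of < 1 uL/min in this assay, at which 2 of the 4 values shown sit.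

The compounds shown do not separate the effect of the ring from that of the amine, so it remains open whether an open chain ending in an amine, such as a 3-aminopropylamino group, or a piperidine ring bearing a hydroxyl in place of the amino group, would give a low number too. On these data alone, how far compound 2 and compound 4 differ also remains open, as does the result for the opposite stereoisomer of the 3-aminopiperidin-1-yl group.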